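The compounds below may be only part of what the source reports. "The series", "measured", "known", "first", "only" and "open" are said of these compounds alone.

Of the compounds shown here, two have been tested so far in a functional assay on the whole organism (strain Wistar) for inhibition, with Rattus norvegicus as the target, read by paw edema, with a stated time of 2 h, at a dose of 10 mg/kg by the intraperitoneal route; on this read-out lower numbers stand for less inhibition and higher numbers for more inhibition at the one dose given (going by the name of the read-out). Compound 1 `O=C(N/N=C/c1ccc(O)c(O)c1)c1cccnc1Nc1cccc(C(F)(F)F)c1` gives 46.9%, the larger of the two numbers, although the gap to compound 2 lies within the usual scatter. Compound 2 `COc1cc(/C=N/NC(=O)c2cccnc2Nc2cccc(C(F)(F)F)c2)cc(OC)c1OC` gives 40.6% in this assay. Compound 3 `O=C(N/N=C/c1ccncc1)c1cccnc1Nc1cccc(C(F)(F)F)c1` has not been measured; it differs from compound 1 in one place: pyridin-4-yl in place of 3,4-dihydroxyphenyl on a carbon with a double bond to nitrogen. Going by the values given here, no measured pair shows what such a change does here, so the step of a number 8.9 percentage points lower from compound 1 to compound 3 (within the scatter) is expected to be small, a slight fall at most or none beyond the scatter. Compound 3 is therefore estimated at 38% in this assay, between 20% and 55%.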

Compound 3, a percentage reported as inhibition, in the whole organism at one dose (the size of the read-out at that dose, not a potency): 65.2%
Compound 3: middle estimate off by 27.2 percentage points, on the low side; measured number outside the range, above it.
By their numbers in this assay, from the lowest: compounds 2 and 1 (each within the scatter of the next); then compound 3.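

Placing pyridin-4-yl in place of 3,4-dihydroxyphenyl on a carbon with a double bond to nitrogen gives a number 18.3 percentage points higher from compound 1 to compound 3 (beyond the scatter) in this assay. This position therefore responds to the choice of ring, and the hydrogen-bond donors of 3,4-dihydroxyphenyl are not needed for inhibition at this dose. No measurement here explains the rise.

Still open, as far as these compounds go, is whether the ring nitrogen or the loss of both hydroxyl groups carries the step, as the two change together. A plain phenyl group in this place would help to separate them.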